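A few compounds are considered here, and "the series" means these few. Any claim that something is new, unique, unknown or untested is made for them only; others in the source may bear on it.

Of the compounds shown here, three built on one shared core have been tested in a functional assay on MOLT-4 cells (Homo sapiens) for inhibition, read by MTT assay, with a stated time of 72 h; on this read-out higher numbers stand for weaker inhibition and lower numbers for stronger inhibition. Compound 1 `COc1cc(NC(C)CCCNC(=O)NNC(=O)Nc2cc(C(F)(F)F)cc(C(F)(F)F)c2)c2ncccc2c1` gives 22000 nM. Compound 2 `COc1cc(NC(C)CCCNC(=O)Nc2ccc(F)cc2)c2ncccc2c1` gives 24000 nM. Compound 3 `COc1cc(NC(C)CCCNC(=O)NNC(=O)Nc2cccc(C(F)(F)F)c2)c2ncccc2c1` gives 36000 nM. Among these, compound 3 gives the largest figure, yet its distance to compound 2 and its distance to compound 1 each lie within the usual scatter of repeated measurements, so the three cannot be told apart on these numbers.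

Compound 4 `COc1cc(NC(C)CCCNC(=O)NNC(=O)Nc2ccc(C(F)(F)F)cc2)c2ncccc2c1` has not been measured. It differs from compound 3 in one place: 4-(trifluoromethyl)phenyl in place of 3-(trifluoromethyl)phenyl on an amide-type nitrogen. The atoms are the same; only where the trifluoromethyl sits on the ring changes.

Among the measured compounds shown here, only one measured step touches this part of the molecule. Taking the trifluoromethyl away entirely gave a 1.6-fold higher number from compound 1 to compound 3 (0.21 log units; within the scatter). If removing the group does not shift the number beyond the scatter, moving it within the ring, as compound 4 does, is unlikely to do more. For the measured compounds named here, no measured pair shows such a move directly, so the expectation rests on that single step.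

The expected step is therefore a 1.2-fold lower number from compound 3 to compound 4 (0.08 log units; within the scatter), nothing beyond the scatter. Compound 4 is estimated to give about 30000 nM, with a range from 12000 nM to 75000 nM.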

Compound 4, half-maximal inhibitory concentration: 24000 nM
Compound 4: the middle estimate sits 1.3-fold (0.10 log units) above what was measured, and the stated range covers the measured number.
By their numbers in this assay, from the lowest: compounds 1, 2, 4 and 3 (each within the scatter of the next).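

In this assay, moving the trifluoromethyl from the 3-(trifluoromethyl)phenyl arrangement to the 4-(trifluoromethyl)phenyl arrangement gives a 1.5-fold lower number from compound 3 to compound 4 (0.18 log units; within the scatter) and so leaves the two arrangements impossible to tell apart on this read-out. The earlier compounds shown here covered only a ring carrying a different number of trifluoromethyl groups, seen as a 1.6-fold higher number from compound 1 to compound 3 (0.21 log units; within the scatter); this pair adds a direct test of the same atoms joined differently, and that change also stays within the scatter. No independent measurement is available here to explain the result or say what this ring does in the cells.

As far as these compounds go, both steps at this position remain within the scatter, so it is still open whether any change on this ring can shift the number beyond it. An amine or a carboxylic acid in place of the trifluoromethyl would test that, as would a longer chain carrying the ring on the amide-type nitrogen.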